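The compounds below may be only part of what the source reports. "The series", "measured", "known", "first", "only" and "open" are said of these compounds alone.

Measured compounds in a functional assay for antagonist activity at proteinase-activated receptor 1 (Homo sapiens); on this read-out higher numbers stand for weaker inhibition and lower numbers for stronger inhibition:
compound 1 `CCCCN(CCCN1CCCCC1)c1cc(-c2ccccc2)no1`: > 40000 nM, a limit of the assay.
compound 2 `c1ccc(-c2cc(N(CCCN3CCCCC3)CC3CCCCC3)on2)cc1`: > 10000 nM, a limit of the assay.

Compound 2 stands only at a limit in this assay. The step that the two limits leave unreadable from compound 1 to compound 2 cannot be read, both ends being limits, the limit of > 40000 nM in this assay, at which 1 of the 2 values shown sits, and (the limit of > 10000 nM in this assay, at which 1 of the 2 values shown sits). Compound 3 `Clc1cccc(CN(CCCN2CCCCC2)c2cc(-c3ccccc3)no2)c1` differs from compound 2 by 3-chlorophenyl in place of cyclohexyl on a saturated chain carbon bound to a nitrogen on an aromatic ring. No readable step bears on this change; nothing beyond the scatter is expected in this assay, with a limit again likely. Compound 3 is estimated at 20000 nM, range 4000 nM to 80000 nM. The expected step is a step that the limit leaves unreadable from compound 2 to compound 3.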

Compound 3, half-maximal inhibitory concentration: 1000 nM
For compound 3 the middle estimate is 20-fold (1.30 log units) above the measured one; measured number outside the range, below it.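

In this assay, 3-chlorophenyl in place of cyclohexyl gives an at least 10-fold lower number from compound 2 to compound 3 (1.00 log units; beyond the scatter), and 3-chlorophenyl in place of propyl gives an at least 40-fold lower number from compound 1 to compound 3 (1.60 log units; beyond the scatter), so this place on the nitrogen-bound chain carbon can move the read-out away from the limits. Compound 2 stands at a limit, so the first step gives only a bound on the size: the limit of > 10000 nM in this assay, at which 1 of the 3 values shown sits. Compound 1 also stands at a limit, so the second step is likewise a bound, and the step between these two limits cannot be read: the limit of > 40000 nM in this assay, at which 1 of the 3 values shown sits.

From the compounds shown here alone, whether the gain follows the aromatic ring or the chlorine remains open. Also open, going by these compounds, is what an unsubstituted benzyl or a 3-methoxybenzyl group would give at this place.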